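The compounds below may be only part of what the source reports. "The series", "measured", "known", "first", "only" and "open" are said of these compounds alone.

Compound 1 `Fc1ccc(Sc2ncnc3[nH]cnc23)cc1` gives 31600 nM
Compound 2 `CSc1ncnc2c1ncn2C1COc2ccccc2CO1` gives 24000 nM
Compound 3 `c1ccc2c(c1)COC(n1cnc3ncnc(OCC4CCCCC4)c31)CO2` gives 13400 nM

In a functional assay on MCF7 cells (Homo sapiens) for antiproliferative activity, read by sulforhodamine B assay, with a stated time of 3 days (a higher number here means a weaker inhibitor, a lower number a stronger inhibitor), compound 3 at 13400 nM lies within the usual scatter of compound 2 and beyond the scatter of compound 1, which has the higher number of that pair. Compound 4 `C=CCOc1ncnc2ncn(C3COc4ccccc4CO3)c12` has not yet been measured. It carries vinyl in place of cyclohexyl on a saturated chain carbon bound to an oxygen on an aromatic ring. Among the measured compounds shown here, no measured pair shows this change alone. The core of compound 3 is shared by the nearest guide, and that guide, compound 2, gives 24000 nM with a different group there. The expected step of a 1.5-fold higher number from compound 3 to compound 4 (0.17 log units; within the scatter) is a small move toward a weaker number, probably within the scatter. The estimate for compound 4 is 20000 nM with 10000 nM to 40000 nM as its expected range.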

Compound 4, half-maximal inhibitory concentration: 20900 nM
Estimate against measurement, compound 4: 1.0-fold (0.02 log units) below; the measured number falls inside the stated range.
By their numbers in this assay, from the lowest: compounds 3, 4, 2 and 1 (each within the scatter of the next, the first and the last beyond it).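

In this assay, among the compounds shown here, the swap of cyclohexyl for vinyl on a saturated chain carbon bound to an oxygen on an aromatic ring is a 1.6-fold higher number from compound 3 to compound 4 (0.19 log units; within the scatter) and gives the first comparison at this position in which only one place differs. The cyclohexyl ring can give way to the much smaller vinyl, with its double bond, and the assay does not separate the two compounds.

Going by these compounds, whether an amine, a carboxylic acid or a longer chain at this position would also leave the number within the scatter stays open, as does whether this swap would read the same on another core. Nothing measured here offers a reason for the result.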